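The source may report more compounds than this note shows. Statements on the series, on what has been measured and on what is new or still open speak of the compounds shown alone.

Measured in an ADME assay on the whole organism (Rattus norvegicus, strain Sprague-Dawley) for pharmacokinetics, using cassette dosing, at a dose of 0.5 mg/kg by the intravenous route; a lower number here means slower removal, a higher number faster removal of the compound:
- compound 1 `O=C(Nc1ccc2[nH]c(=O)oc2c1)C(=O)N1CCN(c2ccc(Cl)cc2)CC1`: 7.2 mL/min/kg
- compound 2 `O=C(Nc1ccc2[nH]c(=O)oc2c1)C(=O)N1CCN(c2ccccc2)CC1`: "not determined" (no result reported)
- compound 3 `O=C(Nc1ccc2[nH]c(=O)oc2c1)C(=O)N1CCN(c2ccc(C(F)(F)F)cc2)CC1`: 15.1 mL/min/kg

Of the two compounds with numbers, compound 3 stands highest at 15.1 mL/min/kg. Compound 4 `O=C(Nc1ccc2[nH]c(=O)oc2c1)C(=O)N1CCN(c2ccc(F)c(F)c2)CC1` brings (3,4-difluorophenyl in place of 4-(trifluoromethyl)phenyl on an amine nitrogen in a ring), with 3,4-difluorophenyl entering on an amine nitrogen in a ring. For the measured compounds named here, one measured step bears on this: a 2.1-fold higher number from compound 1 to compound 3 (0.32 log units; beyond the scatter), a modest step beyond the scatter, where trifluoromethyl replaced chloro. Going by the values given here, no measured compound carries fluoro groups on the aromatic ring, so the guide is indirect. Among the compounds with values here, since trifluoromethyl leaves here, a small move towards a lower number is expected, no larger than that step. The expected change is a 1.5-fold lower number from compound 3 to compound 4 (0.18 log units; within the scatter), which may not exceed the scatter. For compound 4 the estimated value is 10 mL/min/kg, with an expected range of 5 mL/min/kg to 20 mL/min/kg.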

Compound 4, clearance: 4 mL/min/kg
For compound 4 the middle estimate is 2.5-fold (0.40 log units) above the measured one; measured number outside the range, below it.
By their numbers in this assay, from the lowest: compounds 4 and 1 (each within the scatter of the next); then compound 3.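

In this assay, replacing 4-(trifluoromethyl)phenyl with 3,4-difluorophenyl on the ring nitrogen gives a 3.8-fold lower number from compound 3 to compound 4 (0.58 log units; beyond the scatter) and so confirms that the number at this position responds to the aryl group. Replacing 4-chlorophenyl with the same group gives a 1.8-fold lower number from compound 1 to compound 4 (0.26 log units; within the scatter) and separates neither compound, leaving compound 3 alone at the high end. No measurement here accounts for this difference. The compounds shown leave open how a methoxy group or a nitrile on the phenyl ring, or a pyridine in its place, would read in this assay at this position.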